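Mirror-Image Ring Centres and Half-Life in Microsomes

The compounds below may be only part of what the source reports. "The series", "measured", "known", "first", "only" and "open" are said of these compounds alone.

Measured in an in vitro ADME assay on microsomes (Homo sapiens) for metabolic stability; a higher number here means that the compound lasts longer, a lower number that the compound disappears faster:
- Compound 1 `CNC(=O)Nc1ccc(-c2nc(N3CC4CCC(C3)O4)c3cnn([C@H]4CC[C@@H](O)CC4)c3n2)cc1`: > 0.5 h (a limit of the assay, not a number)
- Compound 2 `O=C(Nc1ccc(-c2nc(N3CC4CCC(C3)O4)c3cnn(C4CCC5(CC4)OCCO5)c3n2)cc1)NC1CC1`: 0.15 h

In this assay compound 1 gives > 0.5 h. As far as these compounds go, this is a limit and not a number, so the exact half-life of compound 1 remains unknown. Compound 2 has a numerical half-life of 0.15 h, but it differs from compound 1 in more than one place and offers no clean comparison.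

The next compound is compound 3 `CNC(=O)Nc1ccc(-c2nc(N3CC4CCC(C3)O4)c3cnn([C@H]4CC[C@H](O)CC4)c3n2)cc1`, which has the same atoms and bonds as compound 1. The difference lies only in how the structure is arranged in space: the two compounds have the same atoms and bonds; at least one stereo element is drawn with a configuration in one of them and without one in the other: 2 of 4 stereo elements differ; a stereocentre at a saturated ring carbon is drawn s in compound 1 and r in compound 3; a stereocentre at a saturated ring carbon is drawn s in compound 1 and r in compound 3. The stereocentres at saturated ring carbons that are drawn s in compound 1 are drawn r in compound 3.

For the measured compounds named here, no measured pair shows what this kind of change does in this assay, so no direction can be favoured. I expect no change beyond the scatter. The expected step is a step that the limit leaves unreadable from compound 1 to compound 3. For compound 3 the estimated half-life is 0.6 h, with an expected range from 0.25 h to 1.5 h.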

Compound 3, half-life: > 0.5 h
Compound 3 gave a limit, no number; the forecaster's own chance of this, stated with the estimate: 55%; the middle value lies beyond the limit too.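

In this assay compound 3 gives > 0.5 h as a limit of the assay and not a number. Compound 1 gives > 0.5 h as a limit too. For the compounds shown here, no step between compound 1 and compound 3 can be read from these two limits: the limit of > 0.5 h in this assay, at which 2 of the 3 values shown sit. As far as these compounds go, whether the half-lives of compound 1 and compound 3 truly differ stays open.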